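Aryl replacement at the shared core: lipophilicity notes

A few compounds are considered here, and "the series" means these few. Any claim that something is new, unique, unknown or untested is made for them only; others in the source may bear on it.

Measured so far:
compound 1 `CC[C@@H](Nc1c(C#N)c(-c2ccc(-c3ncccc3C)cc2)nc2cnccc12)C(N)=O` — 2
compound 2 `CC[C@@H](Nc1c(C#N)c(-c2ccc(-c3ccccc3C(F)(F)F)cc2)nc2cnccc12)C(N)=O` — 3.1

In a physicochemical assay for lipophilicity, read by HPLC, at pH 7.5 (a lower number here means a more polar compound, a higher number a more lipophilic compound), compound 2 gives 3.1 and stands highest of the two numbers; its nearest neighbour is compound 1, which in this assay gives 2. Among the compounds with values here, the one step recorded, a number 1.10 log units higher from compound 1 to compound 2 (beyond the scatter), is large and lies beyond the scatter.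

Compound 3 `CC[C@@H](Nc1c(C#N)c(-c2ccc(-c3cccc(Cl)c3F)cc2)nc2cnccc12)C(N)=O` has not been measured. It differs from compound 2 at the same position touched by that step: 3-chloro-2-fluorophenyl in place of 2-(trifluoromethyl)phenyl on an aromatic carbon

The step from compound 1 to compound 2 is the only one that bears on this change, and it concerns a different group leaving than the one leaving here, so it sets only the scale on which this position can move. Both the leaving and the entering group in compound 3 are halogen-bearing phenyl rings with no donors or acceptors, so no step beyond the scatter is expected in this assay, a number 0.10 log units lower from compound 2 to compound 3 (within the scatter). Compound 3 is therefore estimated at 3, within 2.6 to 3.4.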

Compound 3, distribution coefficient: 3.1
The estimate for compound 3 lay 0.10 log units below the measured number, and the stated range covers the measured number.
By their numbers in this assay, from the lowest: compound 1; then compounds 2 and 3 (each within the scatter of the next).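

In this assay, replacing 2-(trifluoromethyl)phenyl with 3-chloro-2-fluorophenyl on this aromatic carbon, para to a large group, gives no change at the digits printed from compound 2 to compound 3 (within the scatter), so these two differently substituted phenyl groups cannot be told apart at this position, even though they share neither substitution pattern nor halogen set. The large step seen earlier is also no longer tied to a single entering group: the series now shows a number 1.10 log units higher from compound 1 to compound 3 (beyond the scatter), which places both rings of carbon only on the same side of the 3-methylpyridin-2-yl compound, beyond the scatter. No supporting measurement is available to account for either the match between the two phenyl compounds or their separation from compound 1.

The compounds shown do not separate the contribution of the ring nitrogen from that of the methyl group in compound 1, and an unsubstituted phenyl or pyridin-2-yl group would be needed to do so. Also open, on these data alone, is how far this position can move in the polar direction when the phenyl ring carries an amine or a carboxylic acid.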